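Solubility of three aryl-substituted analogues on a shared core

The source may hold more compounds than are shown below. What is called first, only, known or untested is meant among the compounds shown, and "the series" means these compounds.

Measured compounds:
compound 1, `CCOC(=O)c1c(-c2cccc(Cl)c2)[nH]c2cccc(OC)c2c1=O`, > 100000 nM
compound 2, `CCOC(=O)c1c(-c2cccc([N+](=O)[O-])c2)[nH]c2cccc(OC)c2c1=O`, 49000 nM

Compound 1 carries a chloro group on its aryl ring. In a physicochemical assay for solubility, in phosphate buffer, at pH 7.4 (a lower number here means a less soluble compound, a higher number a more soluble compound), compound 1 reaches only a limit of the assay, (the limit of > 100000 nM in this assay, at which 1 of the 2 values shown sits), so no number is known for it. For the measured compounds named here, compound 2 carries a nitro group in the same place and is the one compound with a numerical result in this assay, 49000 nM. Going by the values given here, the single measured step, an at least 2.0-fold lower number from compound 1 to compound 2 (0.30 log units; that floor lies within the scatter), is the only comparison available.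

Compound 3, `CCOC(=O)c1c(-c2cccc(C(F)(F)F)c2)[nH]c2cccc(OC)c2c1=O`, has not yet been measured in this assay. It differs from compound 2 as follows: trifluoromethyl in place of nitro on an aromatic carbon. The measured step from chloro to nitro bears on this change only indirectly, since trifluoromethyl is a third group and neither measured compound carries it. With one step that itself sits at the scatter floor and one value that is a limit, no direction can be read off with confidence.

The expectation for compound 3 is therefore a step of a 1.1-fold higher number from compound 2 to compound 3 (0.05 log units; within the scatter), which is no change beyond the scatter. The estimated solubility of compound 3 in this assay is 55000 nM, with a range from 20000 nM to 150000 nM.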

Compound 3, solubility: > 100000 nM
Compound 3: a limit, no number (the forecaster's own chance of this, stated with the estimate: 30%); middle value at least 1.8-fold (0.25 log units) away from the limit.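

Compound 3 now stands with compound 1 at the limit of the assay, which leaves nitro as the only one of the three groups at this position with a numerical result in this assay: the limit of > 100000 nM in this assay, at which 2 of the 3 values shown sit.

Trifluoromethyl in place of nitro gives an at least 2.0-fold higher number from compound 2 to compound 3 (0.30 log units; that floor lies within the scatter), so this change can be read only as a floor, and that floor alone does not clear the scatter. It does give compound 2 a second step, and both of its steps, one from chloro and one to trifluoromethyl, are bounded on the same side by a limit. The step between compound 1 and compound 3 cannot be read, so chloro and trifluoromethyl cannot be placed in any order.

Going by these compounds, how far the true solubility of compound 1 and compound 3 lies beyond the limit stays open, and with it the real size of both steps around nitro. Also open, on these data alone, is what an amine or a carboxylic acid on the same aromatic carbon would read, and whether such a group would give a number or another limit.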